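The source may report more compounds than this note shows. Statements on the series, on what has been measured and on what is new or still open speak of the compounds shown alone.

Compound 1 `COc1ccc2nc(C)cc(NCc3ccncc3)c2c1` – 40900 nM
Compound 2 `COc1ccc2nc(C)cc(NCc3ccc(C(C)(C)C)cc3)c2c1` – 6900 nM

In a functional assay on MCF-10A cells (Homo sapiens) for antiproliferative activity, with a stated time of 48 h (a lower number here means that less compound is needed, a higher number that more compound is needed for the effect), compound 1 has the higher of the two numbers, and its gap to compound 2 lies beyond the scatter. Compound 3 `COc1ccc2nc(C)cc(NCc3cccc(F)c3)c2c1`, not yet measured, carries 3-fluorophenyl in place of pyridin-4-yl on a saturated chain carbon bound to a nitrogen on an aromatic ring on the shared core. Within the data shown here, no step changing one place has been measured, so the only guide is compound 2 at 6900 nM without pyridin-4-yl. A moderate fall, a 2.7-fold lower number from compound 1 to compound 3 (0.44 log units; beyond the scatter) is the expected step. Compound 3 is estimated at 15000 nM (range 6000 nM to 40000 nM).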

Compound 3, half-maximal effective concentration: 11300 nM
Estimate against measurement, compound 3: 1.3-fold (0.12 log units) above; measured number inside the range.
By their numbers in this assay, from the lowest: compounds 2 and 3 (each within the scatter of the next); then compound 1.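

In this assay, among these compounds, 3-fluorophenyl in place of pyridin-4-yl on a saturated chain carbon bound to a nitrogen on an aromatic ring gives the first step that can be read at this position (a 3.6-fold lower number from compound 1 to compound 3 (0.56 log units; beyond the scatter)). A ring of carbon only carrying fluorine therefore gives a modestly lower number here than the ring with a hetero atom. Nothing at hand explains this step. Still open, on these data alone, is whether the step follows the loss of the ring nitrogen or the arrival of the fluorine. A plain phenyl at this place would separate the two, and a 3-chlorophenyl would test whether fluorine itself matters.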